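The source may report more compounds than this note shows. Statements on the series, on what has been measured and on what is new or still open speak of the compounds shown alone.

Measured in a functional assay on PC-3 cells (Homo sapiens) for inhibition; on this read-out higher numbers stand for weaker inhibition and lower numbers for stronger inhibition:
- compound 1 `Cc1c(C(=O)N/N=C\c2ccncc2)oc2cccc(O)c12` gives >= 40000 nM, which is a limit of the assay.
- compound 2 `Cc1ccc(O)c(/C=N\NC(=O)c2oc3cccc(O)c3c2C)c1` gives 7350 nM.
- compound 3 `Cc1c(C(=O)N/N=C\c2cccnc2)oc2cccc(O)c12` gives >= 40000 nM, again a limit of the assay.

Compound 3 thus sits at the limit of >= 40000 nM in this assay, at which 2 of the 3 values shown sit, with no number of its own, so its step to compound 4 `Cc1c(C(=O)N/N=C\c2ccc(Br)cc2O)oc2cccc(O)c12` cannot be read as a plain ratio. The change is 4-bromo-2-hydroxyphenyl in place of pyridin-3-yl on a carbon with a double bond to nitrogen. Going by the values given here, the steps that bear on it are an at least 5.4-fold higher number from compound 2 to compound 3 (0.73 log units; beyond the scatter) and an at least 5.4-fold lower number from compound 1 to compound 2 (0.73 log units; beyond the scatter): in both, the hydroxyl-bearing phenyl gives the lower number and the pyridyl the limit. Among the compounds with values here, the group entering compound 4 resembles the 2-hydroxy-5-methylphenyl of compound 2 in carrying a hydroxyl on an all-carbon ring, but bears bromine rather than methyl, and no measured step shows what that exchange does. The expectation for compound 4 is therefore a lowering of about an at least 5.0-fold lower number from compound 3 to compound 4 (0.69 log units; beyond the scatter), that is, a return from the limit to a number near that of compound 2. Compound 4 is estimated at 8000 nM, with a range from 2500 nM to 30000 nM.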

Compound 4, half-maximal inhibitory concentration: 2050 nM
Estimate against measurement, compound 4: 3.9-fold (0.59 log units) above, and the stated range ends above it.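

On the carbon with a double bond to nitrogen, 4-bromo-2-hydroxyphenyl clearly outperforms both pyridyl groups in this assay, with an at least 19-fold lower number from compound 3 to compound 4 (1.29 log units; beyond the scatter) and an at least 19-fold lower number from compound 1 to compound 4 (1.29 log units; beyond the scatter). The place also separates two hydroxyl-bearing phenyl groups, with a 3.6-fold lower number from compound 2 to compound 4 (0.55 log units; beyond the scatter), so the hydroxyl-bearing phenyl groups shown do not all give the same number. Compound 1 and compound 3 remain at a limit, so the step between them cannot be read and the two steps to compound 4 are bounds only: the limit of >= 40000 nM in this assay, at which 2 of the 4 values shown sit.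

Going by these compounds, how much of the number of compound 4 belongs to the bromine and how much to the hydroxyl remains open; plain phenyl, 4-bromophenyl and 2-hydroxyphenyl would separate the two. Also open, on these data alone, is whether methoxy in place of the hydroxyl, or chlorine in place of the bromine, would keep that number.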